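Aromatase inhibition notes: bromo for methyl on compound 1

The source may report more compounds than this note shows. Statements on the series, on what has been measured and on what is new or still open speak of the compounds shown alone.

Measured so far:
compound 1 `Cc1ccc(-c2cc3ccccc3[nH]2)cc1`: 9.33%
compound 2 `Cn1c(-c2ccc(Cl)c(Cl)c2)cc2cc(N)ccc21`: 42%

In an assay on isolated protein for inhibition of Aromatase (Homo sapiens), read by fluorescence, using NADPH, with a stated time of 30 min, tested at 50 uM (on this read-out lower numbers stand for less inhibition and higher numbers for more inhibition at the one concentration tested (going by the name of the read-out)), compound 1 gives 9.33%, the lowest of the two numbers measured. The nearest number belongs to compound 2, which in this assay gives 42%, higher by a margin beyond the usual scatter. Compound 1 and compound 2 differ in more than one place, so no single step can be read between them; only their two values stand side by side.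

Compound 3 `Brc1ccc(-c2cc3ccccc3[nH]2)cc1` is not yet measured in this assay. Compared with compound 1 it shows one change: bromo in place of methyl on an aromatic carbon. For the measured compounds named here, no step between measured compounds matches this change, so its size has to be guessed from the low reading of compound 1 alone. The expectation is a small step, if any, and not clearly in either direction beyond the scatter.

Compound 3 is estimated at 15% in this assay, with a range from 0% to 35%. That estimate means an expected step of a number 5.7 percentage points higher from compound 1 to compound 3 (within the scatter), which is expected to stay within the scatter.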

Compound 3, a percentage reported as inhibition, at one concentration (the size of the read-out at that concentration, not a potency): 4.8%
Compound 3: the middle estimate sits 10.2 percentage points above what was measured, within the range that was stated.
By their numbers in this assay, from the lowest: compounds 3 and 1 (each within the scatter of the next); then compound 2.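

At the aromatic carbon para to a group of 9 heavy atoms, the series now has its first single-place step in this assay: bromo in place of methyl gives a number 4.5 percentage points lower from compound 1 to compound 3 (within the scatter). Methyl and bromo therefore cannot be told apart at this position on this read-out, and this one exchange on the core of compound 1 offers no route to a clearly different inhibition reading. No supporting measurement is available that could explain why these two groups read alike.

Still open, as far as these compounds go, is whether a group of a different kind at this same position, such as a carboxylic acid, a methoxy group or a longer alkyl chain, would produce a step beyond the scatter. Also open is which structural feature goes with the reading of compound 2 at 42%, since no single-place step connects compound 2 to the other compounds shown and its several differences cannot be separated.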